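Hydroxyphenyl position shift on a shared pyridine core

The source may hold more compounds than are shown below. What is called first, only, known or untested is meant among the compounds shown, and "the series" means these compounds.

Measured compounds:
compound 1 `Oc1ccc(-c2cc(-c3cccc(Cl)c3)nc(-c3ccccn3)c2)cc1` 59.4%
compound 2 `Oc1cccc(-c2cc(-c3ccc(Cl)cc3)nc(-c3ccccn3)c2)c1` 30%

In an assay on isolated protein for inhibition of DNA topoisomerase 1 (Homo sapiens), with a stated time of 30 min, tested at 100 uM (a higher number here means a stronger effect of the compound at the concentration tested, a lower number a weaker effect), compound 2 gives the lower of the two numbers, while compound 1 gives 59.4%, a value beyond the scatter above it. Within the data shown here, the two differ in more than one place, so no single step links them. Compound 3 `Oc1ccc(-c2cc(-c3ccc(Cl)cc3)nc(-c3ccccn3)c2)cc1` is not yet measured; it differs from compound 2 by 4-hydroxyphenyl in place of 3-hydroxyphenyl on an aromatic carbon. Compound 1 also carries a 4-hydroxyphenyl group, so a rise is expected, though of uncertain size. Compound 3 is expected to give 47%, between 27% and 67%, an estimated step of a number 17 percentage points higher from compound 2 to compound 3 (beyond the scatter).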

Compound 3, a percentage reported as inhibition, at one concentration (the size of the read-out at that concentration, not a potency): 12.7%
For compound 3 the middle estimate is 34.3 percentage points above the measured one; measured number outside the range, below it.
By their numbers in this assay, from the lowest: compound 3; then compound 2; then compound 1.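

Compound 3 shows that 4-hydroxyphenyl brings no gain of its own at this position: in this assay the change from 3-hydroxyphenyl gives a number 17.3 percentage points lower from compound 2 to compound 3 (beyond the scatter) on the shared core. The chlorophenyl group also matters alongside 4-hydroxyphenyl, since 4-chlorophenyl in place of 3-chlorophenyl gives a number 46.7 percentage points lower from compound 1 to compound 3 (beyond the scatter) in the same read-out. Nothing available bears on the reason for either drop.

Going by these compounds, it remains open how 3-hydroxyphenyl behaves together with 3-chlorophenyl. On these data alone, it is also open whether an amine or a methoxy group could stand in for the hydroxyl.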